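Iodo for fluoro on the shared core: a second instance

The source may report more compounds than this note shows. Statements on the series, on what has been measured and on what is new or still open speak of the compounds shown alone.

In a functional assay on THP-1 cells (Homo sapiens) for inhibition, read by sulforhodamine B assay, with a stated time of 48 h, tested at 50 uM (a higher number here means more inhibition of growth at the concentration tested, a lower number less inhibition of growth), compound 1 `O=C1C(=O)N(CCCn2cc(COc3cc(=O)oc4ccccc34)nn2)c2ccc(I)cc21` gives 67%.
In this assay compound 2 `O=C1C(=O)N(CCCn2cc(COc3cc(=O)oc4ccccc34)nn2)c2ccc(F)cc21` gives 86%.
In this assay compound 3 `O=C1C(=O)N(CCCCn2cc(COc3cc(=O)oc4ccccc34)nn2)c2ccc(F)cc21` gives 77%.

Compound 4 `O=C1C(=O)N(CCCCn2cc(COc3cc(=O)oc4ccccc34)nn2)c2ccc(I)cc21` has not been measured. It stands to compound 3 as compound 1 stands to compound 2: iodo in place of fluoro on an aromatic carbon, the same kind of change as iodo in place of fluoro on an aromatic carbon, with the place described identically in both. The difference between the cores of compound 2 and compound 3 is not broken down here. For the measured compounds named here, the one measured instance of the change is a number 19 percentage points lower from compound 2 to compound 1 (beyond the scatter). Compound 3 lies within the scatter of compound 2 and also of compound 1, so nothing separates it from either. The expectation for compound 4 rests on that single step alone. A downward step of similar size is expected, a number 19 percentage points lower from compound 3 to compound 4 (beyond the scatter), because a number 19 percentage points lower from compound 2 to compound 1 (beyond the scatter). Compound 4 is therefore estimated at 58%, with a range from 45% to 72%.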

Compound 4, percent growth inhibition at one concentration: 59%
Estimate against measurement, compound 4: 1 percentage points below; the range from low to high includes it.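

In this assay, iodo in place of fluoro on an aromatic carbon gives a number 18 percentage points lower from compound 3 to compound 4 (beyond the scatter), and the step on the other core matches it: the same change on two cores in this assay, a number 19 percentage points lower (beyond the scatter) from compound 2 to compound 1 and a number 18 percentage points lower (beyond the scatter) from compound 3 to compound 4, 1 percentage points apart, within the scatter of two such steps. Within these two cores, the change therefore carries over with its direction and size intact, at the one concentration tested. This does not establish a rule for cores beyond these two, and the four compounds give no reason for the step.

As far as these compounds go, only fluoro and iodo appear at this place, so it remains open how chloro or bromo would read on either core. Also open, from the compounds shown here alone, are an amine or a carboxylic acid on that carbon, and a longer chain than that of compound 4.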